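The source may hold more compounds than are shown below. What is called first, only, known or untested is meant among the compounds shown, and "the series" means these compounds.

Compound 1, with the structure `COC(=O)c1ccc2ccc(C(=O)c3ccccc3)c-2cc1`, is the reference point of this small set. In an assay on cells for displacement of a labelled ligand from Orexin receptor type 2 (Homo sapiens), read by scintillation counting, with stated times of 10 min and 90 min, tested at 10 uM (a lower number here means less inhibition, a higher number more inhibition at the concentration tested (going by the name of the read-out)), compound 1 gives 28.9%, the highest of the three numbers recorded. Compound 2, with the structure `COC(=O)c1ccc2c(C(=O)c3ccccc3)cc(C(=O)c3ccccc3)c-2cc1`, carries a second benzoyl group and gives -14.5%; the step of a number 43.4 percentage points lower from compound 1 to compound 2 (beyond the scatter) is large. Compound 3, with the structure `COC(=O)c1ccc2c(I)cc(C(=O)c3ccccc3)c-2cc1`, gives -5.4%, and the step of a number 34.3 percentage points lower from compound 1 to compound 3 (beyond the scatter) is also large. Between the two compounds with the lower numbers the step of a number 9.1 percentage points higher from compound 2 to compound 3 (within the scatter) stays within the scatter.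

Compound 4, with the structure `COC(=O)Cc1ccc2ccc(C(=O)c3ccccc3)c-2cc1`, differs from compound 1 in a different place from those two steps: (methoxycarbonyl)methyl in place of methoxycarbonyl on an aromatic carbon. Neither measured step touches the methoxycarbonyl group, so none of them bears directly on this change, and no guide to its size exists among the three measured compounds. The change inserts one carbon between the ring and the ester without altering the count of hydrogen-bond acceptors, so a small step is expected, most likely within the scatter and with a slight lean downward. For compound 4 an inhibition of about 22% is estimated, within a range from 0% to 45%, which means an expected step of a number 6.9 percentage points lower from compound 1 to compound 4 (within the scatter).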

Compound 4, a percentage reported as inhibition, at one concentration (the size of the read-out at that concentration, not a potency): -4.3%
Compound 4: middle estimate off by 26.3 percentage points, on the high side; measured number outside the range, below it.
By their numbers in this assay, from the lowest: compounds 2, 3 and 4 (each within the scatter of the next, the first and the last beyond it); then compound 1.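

In this assay the place that carries the ester turns out to matter: putting (methoxycarbonyl)methyl in place of methoxycarbonyl on an aromatic carbon of a seven-membered aromatic ring of carbon only gives a number 33.2 percentage points lower from compound 1 to compound 4 (beyond the scatter), even though the two groups have equal counts of hydrogen-bond donors and acceptors and neither has a net charge. Among these compounds, the earlier steps all left this group untouched, so this is the first sign that a change here, and not only changes elsewhere on the core, can bring the number well down from that of compound 1. No supporting data on this series bear on why so modest a change in the group gives so large a step.

The compounds shown leave open how other groups at this place would behave, such as a carboxylic acid, a primary amide or a longer chain ending in the ester. They also leave open whether the same change would give a step of similar size in compound 2 or compound 3, which already differ from compound 1 elsewhere.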